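A Smaller Substituent on the Shared Core

The source may report more compounds than this note shows. Statements on the series, on what has been measured and on what is new or still open speak of the compounds shown alone.

Of the compounds shown here, three on a shared core have been measured so far. In a physicochemical assay on HT-29 cells for lipophilicity (on this read-out lower numbers stand for lower lipophilicity and higher numbers for higher lipophilicity), compound 1 `COCCc1cccc(Nc2n[n+]([O-])c3ccccc3[n+]2[O-])c1` gives 1.51. In this assay compound 2 `CCN(CC)c1cccc2c1[n+]([O-])nc(N)[n+]2[O-]` gives 0.83, and compound 3 `Cc1ccc2c(c1)[n+]([O-])nc(N)[n+]2[O-]` gives 0.127. Compound 2 thus stands second highest of the three: compound 1 lies higher by a margin beyond the scatter, and compound 3 lies lower by a margin beyond the scatter. Compound 4 `Cc1cccc2c1[n+]([O-])nc(N)[n+]2[O-]` has not yet been measured. It differs from compound 2 in one place: methyl in place of diethylamino on an aromatic carbon. The step from compound 2 to compound 4 is expected to run downward and beyond the scatter, at a number 0.63 log units lower from compound 2 to compound 4 (beyond the scatter), because compound 3 with its own methyl gives 0.127. Compound 4 is therefore estimated at 0.2, within a range from -0.3 to 0.7.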

Compound 4, partition coefficient: 0.24
Compound 4: middle estimate off by 0.04 log units, on the low side, within the range that was stated.
By their numbers in this assay, from the lowest: compounds 3 and 4 (each within the scatter of the next); then compound 2; then compound 1.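

In this assay, among the compounds shown here, a number 0.59 log units lower from compound 2 to compound 4 (beyond the scatter) accompanies the exchange of diethylamino for methyl on this aromatic carbon, the first change at a single place on the shared core. For the compounds shown here, it shows that this position alone can move the number by a margin beyond the scatter, which the earlier compounds, differing in more than one place, could not show. Nothing at hand accounts for the step. On these data alone, whether an ethyl or a dimethylamino group on this carbon would fall between these two numbers remains open. As far as these compounds go, what a carboxylic acid would give there remains open too.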